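Methyl on the aromatic oxygen: compound 3 to compound 4

The source may report more compounds than this note shows. Statements on the series, on what has been measured and on what is new or still open speak of the compounds shown alone.

Measured so far:
compound 1 `CCOCc1c(C)coc1-c1ccc2c(c1OC)CCCC2(C)C` — 19.8 uM
compound 2 `COC(=O)c1c(C)coc1-c1ccc2c(c1OC)CCCC2(C)C` — 34.5 uM
compound 3 `Cc1coc(-c2ccc3c(c2O)CCCC3(C)C)c1C(=O)O` — 1.7 uM

In a functional assay on ZR-75-1 cells (Homo sapiens) for cytotoxicity, read by sulforhodamine B assay, with a stated time of 3 days (a lower number here means that less compound is needed, a higher number that more compound is needed for the effect), compound 3 gives the lowest number of the three; compound 1 and compound 2, both carrying a methoxy on the shared core, sit well above it, beyond the scatter. Compound 4 `COc1c(-c2occ(C)c2C(=O)O)ccc2c1CCCC2(C)C` follows from compound 3 by methyl in place of hydrogen on an oxygen on an aromatic ring. Among the compounds with values here, the only measured step, a 1.7-fold higher number from compound 1 to compound 2 (0.24 log units; within the scatter), concerns a different position and says nothing about this change. What can be read is that compound 1 and compound 2 with methoxy both sit far above compound 3 with hydroxy. A higher number is therefore expected for compound 4, a 7.1-fold higher number from compound 3 to compound 4 (0.85 log units; beyond the scatter). Compound 4 is estimated at 12 uM, between 4 uM and 35 uM.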

Compound 4, concentration for half-maximal effect: 41.4 uM
Estimate against measurement, compound 4: 3.5-fold (0.54 log units) below, and the stated range ends below it.
By their numbers in this assay, from the lowest: compound 3; then compounds 1, 2 and 4 (each within the scatter of the next, the first and the last beyond it).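

With the carboxy held in place, hydroxy to methoxy alone gives a 24-fold higher number from compound 3 to compound 4 (1.39 log units; beyond the scatter) in this assay and is the large change in this set. Once the methoxy is present, the other site matters little: a 1.2-fold higher number from compound 2 to compound 4 (0.08 log units; within the scatter) for hydrogen in place of the ester methyl, while a 2.1-fold higher number from compound 1 to compound 4 (0.32 log units; beyond the scatter) for carboxy in place of ethoxymethyl is only a modest step. Nothing measured explains the size of the methoxy step. Open, going by these compounds, are how ethoxy or an amine on that aromatic carbon would read, and whether hydroxy also gives a low number with ethoxymethyl or methoxycarbonyl on the shared core.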